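The source may hold more compounds than are shown below. What is called first, only, known or untested is meant among the compounds shown, and "the series" means these compounds.

Compound 1 `O=C(C1=C(OC2CCCCC2)C(=O)N(CCCn2ccnc2)C1c1ccc(Br)cc1)c1ccccc1` and compound 2 `O=C(C1=C(Nc2ccccc2)C(=O)N(CCCn2ccnc2)C1c1ccc(Br)cc1)c1ccccc1` share one core and differ in a single group. In a functional assay on A549 cells (Homo sapiens) for antiproliferative activity, read by MTT assay, with a stated time of 72 h (a higher number here means a weaker inhibitor, a lower number a stronger inhibitor), compound 1 gives 31200 nM, and compound 2 gives 24100 nM. Putting an anilino group in place of the cyclohexyloxy group gave a 1.3-fold lower number from compound 1 to compound 2 (0.11 log units; within the scatter), a change too small to count. Going by the values given here, compound 2 thus holds the lower of the two numbers measured so far, but compound 1 sits within the scatter of it, so neither can be called the stronger inhibitor.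

Compound 3 `O=C(C1=C(Nc2cccc(Br)c2)C(=O)N(CCCn2ccnc2)C1c1ccc(Br)cc1)c1ccccc1` has not yet been measured. It differs from compound 2 by bromo in place of hydrogen on an aromatic carbon, placed meta to a large group on the ring of the anilino substituent. Among the compounds with values here, no measured step touches that ring; the only step on record swaps the whole group and says nothing about a bromine added to it. With nothing pointing either way, compound 3 is expected to stay close to compound 2, with no step beyond the scatter in this assay. The step of a 1.2-fold lower number from compound 2 to compound 3 (0.08 log units; within the scatter) is expected to be small. In this assay compound 3 is estimated at 20000 nM, within a range from 8000 nM to 50000 nM.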

Compound 3, half-maximal inhibitory concentration: 15800 nM
Compound 3: the middle estimate sits 1.3-fold (0.10 log units) above what was measured; the measured number falls inside the stated range.
By their numbers in this assay, from the lowest: compounds 3, 2 and 1 (each within the scatter of the next).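

Adding a bromo group to the ring of the anilino substituent, on an aromatic carbon, gave a 1.5-fold lower number from compound 2 to compound 3 (0.18 log units; within the scatter) in this assay, so this position accepts a bromine atom without a step beyond the scatter. Going by these compounds alone, this is the first measured change made on that ring itself, since the earlier step replaced the whole group at once. The full replacement of cyclohexyloxy by (3-bromophenyl)amino gave a 2.0-fold lower number from compound 1 to compound 3 (0.30 log units; within the scatter), which also lies within the scatter, so these results still provide no firm ranking of the compounds, and no available evidence accounts for the size of either step.

As far as these compounds go, whether a different group at this same place on the ring, such as a chlorine atom, a methoxy group or a carboxylic acid, would produce a step beyond the scatter remains open. Also open is whether replacing the bromine on the aromatic ring of the shared core with an amine or a longer chain would shift the number more than the changes shown here.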